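The source may hold more compounds than are shown below. What is called first, only, known or untested is meant among the compounds shown, and "the series" means these compounds.

Compound 1, `Cc1cccc(CN2CC=C(CCC(=O)NO)C2=O)c1`, gives 3330 nM.
Compound 2, `CCOc1ccc(CCCN2CC=C(CCC(=O)NO)C2=O)cc1`, gives 3330 nM.
Compound 3, `O=C(CCC1=CCN(CCCCc2ccc(Cl)cc2)C1=O)NO`, gives 3730 nM.

All three were tested in a functional assay on ACHN cells (Homo sapiens) for inhibition, read by sulforhodamine B assay; on this read-out higher numbers stand for weaker inhibition of growth and lower numbers for stronger inhibition of growth. The three compounds share a core carrying a hydroxamic acid side chain, and they differ only in the aromatic tail attached through a linker of varying length. Compound 2 stands level with compound 1 at the digits shown, and the two together hold the lowest numbers of the three; compound 3 sits a little higher, but that gap is within the scatter of repeated measurements, so the three numbers cannot be told apart with confidence.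

Compound 4, `Cc1ccc(CCCN2CC=C(CCC(=O)NO)C2=O)cc1`, has not yet been measured. It keeps the core and the three-carbon linker of compound 2 and changes only one thing: methyl in place of ethoxy on an aromatic carbon. Among the compounds with values here, no pair of measured compounds shows this kind of swap, so there is no measured step to lean on. Given how closely the three measured tails agree, the expected step of a 1.1-fold higher number from compound 2 to compound 4 (0.02 log units; within the scatter) is no change beyond the scatter. On that basis compound 4 is expected to give about 3500 nM, most likely between 1500 nM and 8000 nM.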

Compound 4, concentration for 50% growth inhibition: 3330 nM
For compound 4 the middle estimate is 1.1-fold (0.02 log units) above the measured one; low and high end bracket the measured number.
By their numbers in this assay, from the lowest: compounds 1, 2, 4 and 3 (each within the scatter of the next).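

In this assay, the step with methyl in place of ethoxy reads no change at the digits printed from compound 2 to compound 4 (within the scatter), and this is the only pair shown that differs in one place. The earlier compounds shown here differ from one another in more than one part of the tail, so they could not show what a change at this one position does. Here, on an aromatic carbon para to a large group, ethoxy with its 3 heavy atoms and 1 hydrogen-bond acceptor leaves, methyl with its 1 heavy atom and no acceptor enters, and the read-out does not move beyond the scatter, though nothing shown gives a reason for this.

The compounds shown leave open whether this position would hold the same level with a quite different group, such as an amine, a carboxylic acid or a longer chain like butoxy. They also leave open whether an unsubstituted ring, with only hydrogen at this carbon, would stay at the same level on this tail.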